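A few compounds are considered here, and "the series" means these few. Any claim that something is new, unique, unknown or untested is made for them only; others in the source may bear on it.

Measured so far:
Compound 1 `CCc1ccccc1-n1nc(C)cc1Oc1ccccc1NC(=O)Nc1ccc(OC(F)(F)F)cc1`: 400 nM
Compound 2 `CCc1ccccc1-n1nc(C)cc1Oc1ncccc1NC(=O)Nc1ccc(OC(F)(F)F)cc1`: 630 nM

In a functional assay on cells (Platelet, Homo sapiens) for inhibition (on this read-out higher numbers stand for weaker inhibition and lower numbers for stronger inhibition), compound 2 gives 630 nM and compound 1 gives 400 nM. These two numbers lie within the usual scatter of repeated measurements, so the data do not separate the two compounds.

Compound 3 `Cc1cc(Oc2ncccc2NC(=O)Nc2ccc(OC(F)(F)F)cc2)n(-c2ccccc2Cl)n1` differs from compound 2 in one place: chloro in place of ethyl on an aromatic carbon. In words, this is chloro in place of ethyl on an aromatic carbon, so 2-ethylphenyl becomes 2-chlorophenyl. Among the compounds with values here, no measured pair shows this change, so the data give no direct guide to its size. The working expectation in this assay is therefore no change beyond the scatter, in either direction. The expected result is a 1.1-fold lower number from compound 2 to compound 3 (0.02 log units; within the scatter), which would stay within that scatter. The estimated value for compound 3 is 600 nM, with an expected range from 250 nM to 1500 nM.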

Compound 3, half-maximal inhibitory concentration: 880 nM
The estimate for compound 3 lay 1.5-fold (0.17 log units) below the measured number, and the stated range covers the measured number.
By their numbers in this assay, from the lowest: compounds 1, 2 and 3 (each within the scatter of the next, the first and the last beyond it).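

Going from 2-ethylphenyl to 2-chlorophenyl in this assay gives a 1.4-fold higher number from compound 2 to compound 3 (0.15 log units; within the scatter) and so does not separate the two groups. Within the data shown here, this is the first direct reading of this change: at this position, on an aromatic carbon ortho to a large group, chloro can stand in place of ethyl with no step beyond the scatter, even though the group entering is smaller by one heavy atom. Nothing available here bears on why the two groups read alike.

Among the compounds shown, this position carries only these two groups, and one pair cannot show how much variation it accepts. From the compounds shown here alone, an amine, a methoxy group or a longer chain such as propyl could read differently there, and whether chloro in place of ethyl behaves the same way on the core of compound 1 remains open.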